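The source may report more compounds than this note shows. Statements on the series, on what has been measured and on what is new or still open speak of the compounds shown alone.

Compound 1 `C=C(Br)C(=O)Nc1ccc2c(c1)/C(=C\c1ccsc1)C(=O)N2`: in a functional assay on CCRF-CEM cells (Homo sapiens) for antiproliferative activity, read by MTT assay, with a stated time of 72 h (on this read-out higher numbers stand for weaker inhibition and lower numbers for stronger inhibition), compound 1 gives 96 nM.
Compound 2 `C=C(Br)C(=O)Nc1ccc2c(c1)/C(=C\c1sccc1C)C(=O)N2`: compound 2 gives 0.9 nM.
Compound 3 `C=C(Br)C(=O)Nc1ccc2c(c1)/C(=C/c1ccsc1)C(=O)N2`: compound 3 gives 4 nM.

Compound 3 stands second highest of the three numbers, with compound 2 the nearest and compound 1 the furthest. Compound 4 `C=C(Br)C(=O)Nc1ccc2c(c1)/C(=C/c1sccc1C)C(=O)N2` has not yet been measured; it differs from compound 3 in 3-methylthiophen-2-yl in place of thiophen-3-yl on a double-bonded chain carbon bound to a double-bonded ring carbon. For the measured compounds named here, two measured steps bear on this. The same exchange of ring gave a 110-fold lower number from compound 1 to compound 2 (2.03 log units; beyond the scatter), and the change in drawn configuration, (the fact that compounds 1 and 3 differ only in the configuration as drawn), gave a 24-fold lower number from compound 1 to compound 3 (1.38 log units; beyond the scatter). Going by the values given here, compound 4 joins both changes, so a lower number than compound 3 is expected, though compound 2 already sits low and the step is expected to fall short of the one seen from compound 1. The estimate for compound 4 in this assay is 0.5 nM, from 0.1 nM to 3 nM, meaning an 8.0-fold lower number from compound 3 to compound 4 (0.90 log units; beyond the scatter).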

Compound 4, half-maximal inhibitory concentration: 0.5 nM
Compound 4: middle estimate and measured number agree at the digits printed; the range from low to high includes it.
By their numbers in this assay, from the lowest: compounds 4 and 2 (each within the scatter of the next); then compound 3; then compound 1.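

In this assay, the exchange of ring still counts on the Z-drawn pair, giving an 8.0-fold lower number from compound 3 to compound 4 (0.90 log units; beyond the scatter), but it is far smaller there than on the E-drawn pair, so its size depends on the configuration of the double bond: (the same change on two cores in this assay, a 110-fold lower number (2.03 log units; beyond the scatter) from compound 1 to compound 2 and an 8.0-fold lower number (0.90 log units; beyond the scatter) from compound 3 to compound 4, 13-fold (1.12 log units) apart, beyond the scatter of two such steps). For the compounds shown here, with 3-methylthiophen-2-yl in place, configuration no longer separates the compounds, the step being a 1.8-fold lower number from compound 2 to compound 4 (0.26 log units; within the scatter), unlike the large step seen with thiophen-3-yl: (the fact that compounds 2 and 4 differ only in the configuration as drawn). The exchange alters both the methyl and the point of attachment, and these compounds do not separate the two. Thiophen-2-yl, or an ethyl or methoxy group in place of that methyl, remains open.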